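Replacing piperazin-1-yl in compound 3 with an open chain

This account rests on a few compounds, and the source may have more. Where it says the series, first, only, none or still open, it means among the compounds named here.

compound 1 `CC(C)c1n[nH]c2c(NCc3ccc(-c4ccccn4)cc3)nc(NCC(C)(C)O)nc12`: 24 nM
compound 2 `CC(C)c1n[nH]c2c(NCc3ccc(-c4ccccn4)cc3)nc(NCCN)nc12`: 62 nM
compound 3 `CC(C)c1n[nH]c2c(NCc3ccc(-c4ccccn4)cc3)nc(N3CCNCC3)nc12`: 21 nM

In a functional assay on MCF7 cells (Homo sapiens) for cytotoxicity, read by fluorescence, with a stated time of 72 h (on this read-out higher numbers stand for weaker inhibition and lower numbers for stronger inhibition), compound 3 gives 21 nM. The numbers place it level with one neighbour, a 1.1-fold lower number from compound 1 to compound 3 (0.06 log units; within the scatter), and apart from the other, a 3.0-fold lower number from compound 2 to compound 3 (0.47 log units; beyond the scatter).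

The next candidate is compound 4 `CC(C)c1n[nH]c2c(NCc3ccc(-c4ccccn4)cc3)nc(NCCN(C)C)nc12`, with (2-(dimethylamino)ethyl)amino in place of piperazin-1-yl on an aromatic carbon. Among the measured compounds shown here, the nearest precedent is compound 2, which bears (2-aminoethyl)amino on that carbon and marks the larger of the two exchanges with piperazin-1-yl: a 3.0-fold lower number from compound 2 to compound 3 (0.47 log units; beyond the scatter). Compound 1 also has an open chain there, yet shows a 1.1-fold lower number from compound 1 to compound 3 (0.06 log units; within the scatter), so a chain in that place does not always go with a change. The two chains themselves differ: a 2.6-fold higher number from compound 1 to compound 2 (0.41 log units; beyond the scatter).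

Weighing these, a small step to a higher number, near the edge of the scatter, is expected: a 1.9-fold higher number from compound 3 to compound 4 (0.28 log units; within the scatter). Compound 4 is estimated at 40 nM, with an expected range from 15 nM to 105 nM.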

Compound 4, half-maximal inhibitory concentration: 225 nM
Compound 4: the middle estimate sits 5.6-fold (0.75 log units) below what was measured, and the stated range ends below it.
By their numbers in this assay, from the lowest: compounds 3 and 1 (each within the scatter of the next); then compound 2; then compound 4.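

Piperazin-1-yl and (2-(dimethylamino)ethyl)amino have the same heavy-atom, donor and acceptor counts, yet in this assay the exchange gives an 11-fold higher number from compound 3 to compound 4 (1.03 log units; beyond the scatter), so at this aromatic carbon, matched counts do not keep the number level. Among the compounds shown here, the end of the chain also matters, as dimethylamino in place of amino gives a 3.6-fold higher number from compound 2 to compound 4 (0.56 log units; beyond the scatter), and the gap to the hydroxy-bearing chain is wider still, with a 9.4-fold higher number from compound 1 to compound 4 (0.97 log units; beyond the scatter), making compound 4 the weakest of the open chains and of the series so far. Nothing at hand explains these steps.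

Still open, on these data alone, is whether a methylamino end on the same chain would fall with amino or with dimethylamino. Also open, as far as these compounds go, is whether a methyl on the free nitrogen of piperazin-1-yl would bring a similar rise in the ring.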